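Lengthening the acid chain of a weak sulfonamide

The source may hold more compounds than are shown below. What is called first, only, known or untested is meant among the compounds shown, and "the series" means these compounds.

Of the compounds shown here, three have been measured in an assay on HEK293 cells for inhibition of prostaglandin E2 receptor EP2 subtype (Rattus norvegicus); on this read-out higher numbers stand for weaker inhibition and lower numbers for stronger inhibition. Compound 1, `CCCCCC(=O)c1ccc(CN(CCCCCCC(=O)O)S(C)(=O)=O)cc1`, gives 636 nM in this assay. Compound 3, `CC(C)(C)c1ccc(CN(Cc2cccc(OCC(=O)O)c2)S(C)(=O)=O)cc1`, gives 792 nM in this assay; the two values lie within the usual scatter of each other, so no order between them is claimed. Compound 2, `CCCCCC(O)CCCN(CCCCC(=O)O)S(C)(=O)=O`, reaches only > 3200 nM in this assay, which is a limit of the assay and not a number. Among the three values shown, compound 2 alone sits at the limit of > 3200 nM in this assay, at which 1 of the 3 values shown sits, so the numbers give it no exact place, only a position at the weak end.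

Compound 4, `CCCCCC(O)CCCN(CCCCCC(=O)O)S(C)(=O)=O`, has not yet been measured. It differs from compound 2 in one place: carboxymethyl in place of carboxy on a saturated chain carbon, four bonds along the chain from a sulfonamide nitrogen. The acid therefore sits one chain carbon further from the sulfonamide nitrogen. Because compound 2 gives only > 3200 nM, no measured step exists from which the size of this change could be read, and no evidence about its effect is shown.

The step from compound 2 to compound 4 is expected to be a step that the limit leaves unreadable from compound 2 to compound 4, that is, no change beyond the scatter. Compound 4 is expected to give about 4000 nM, within a range of 1200 nM to 14000 nM.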

Compound 4, half-maximal inhibitory concentration: 910 nM
The estimate for compound 4 lay 4.4-fold (0.64 log units) above the measured number; measured number outside the range, below it.
By their numbers in this assay, from the lowest: compounds 1, 3 and 4 (each within the scatter of the next). At a limit, above all of these: compound 2.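

In this assay, carboxymethyl in place of carboxy on a saturated chain carbon, four bonds along the chain from a sulfonamide nitrogen, gives an at least 3.5-fold lower number from compound 2 to compound 4 (0.54 log units; beyond the scatter). This is the first measured step among these compounds, and it shows that the read-out responds at this position: moving the acid one chain carbon further from the sulfonamide nitrogen, with the rest of the molecule unchanged, is enough to take the number beyond the scatter. The full size of the step cannot be read, because compound 2 stands at a limit of the assay and not at a number: the limit of > 3200 nM in this assay, at which 1 of the 4 values shown sits.

This single pair does not establish a trend, so the compounds shown leave open whether one more chain carbon on compound 4, with nothing else altered, would lower the number further, hold it level or raise it. They also leave open whether the carboxylic acid itself is needed at this position, since nothing shown tells what a primary amide or a sulfonic acid in place of the carboxy group would do.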